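Sulfonylurea series: tert-butyl to pentyl on the urea nitrogen

The compounds below may be only part of what the source reports. "The series", "measured", "known", "first", "only" and "open" are said of these compounds alone.

Two members of the series have numbers in a functional assay on HEK293 cells for antagonist activity at thromboxane A2 receptor (Homo sapiens), read by fluorescence and calcium flux; a lower number here means a stronger inhibitor, a higher number a weaker inhibitor. Compound 1 `CC(C)NC(=O)NS(=O)(=O)c1cc(C#N)ccc1Oc1ccc(F)cc1` gives 9300 nM. Compound 2 `CC(C)(C)NC(=O)NS(=O)(=O)c1cc(C#N)ccc1Oc1ccc(F)cc1` gives 3890 nM, the lower of the two, with the step of a 2.4-fold lower number from compound 1 to compound 2 (0.38 log units; beyond the scatter). Compound 3 `CCCCCNC(=O)NS(=O)(=O)c1cc(C#N)ccc1Oc1ccc(F)cc1` carries pentyl in place of tert-butyl on an amide-type nitrogen. Among the measured compounds shown here, the measured step concerns added branching, not a longer unbranched chain, so it bears only loosely on this change; no step of this kind is known. For compound 3 the expected step is a 1.3-fold higher number from compound 2 to compound 3 (0.11 log units; within the scatter), with wide uncertainty. Compound 3 is thus estimated at 5000 nM, within 1500 nM to 15000 nM.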

Compound 3, half-maximal inhibitory concentration: 9530 nM
For compound 3 the middle estimate is 1.9-fold (0.28 log units) below the measured one, within the range that was stated.
By their numbers in this assay, from the lowest: compound 2; then compounds 1 and 3 (each within the scatter of the next).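

At this amide-type nitrogen, pentyl in place of tert-butyl gives a 2.4-fold higher number from compound 2 to compound 3 (0.39 log units; beyond the scatter) in this assay, so the unbranched chain does not hold the lower number. Pentyl and isopropyl sit level, with a 1.0-fold higher number from compound 1 to compound 3 (0.01 log units; within the scatter), so among these groups only tert-butyl stands apart. No measured evidence accounts for this difference.

Still open, from the compounds shown here alone, is whether other branched groups, such as neopentyl or cyclohexyl, behave like tert-butyl. Also open, going by these compounds, is whether a shorter ethyl chain or a longer octyl chain departs from the pentyl result at this nitrogen.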